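A few compounds are considered here, and "the series" means these few. Any claim that something is new, unique, unknown or untested is made for them only; others in the source may bear on it.

Compounds measured in a functional assay on the whole organism with Mus musculus as the target, in the rotarod test; a higher number here means that more compound is needed for the effect, a lower number that less compound is needed:
Compound 1, `CN(C(=O)CNC(=O)CN1CCCCC1)c1ccc(Cl)cc1C(=O)c1ccccc1Cl` — for compound 1 this assay reports only a limit, > 100 mg/kg.
Compound 2, `NCC(=O)NCC(=O)Nc1ccc([N+](=O)[O-])cc1C(=O)c1ccccc1` — compound 2 gives 24.8 mg/kg.
Compound 3, `CN(C(=O)CNC(=O)CN)c1ccc([N+](=O)[O-])cc1C(=O)c1ccccc1` — compound 3 gives 2.94 mg/kg.

Within the data shown here, compound 1 therefore stands apart from the other two: it is the one compound sitting at the limit of > 100 mg/kg in this assay, at which 1 of the 3 values shown sits, so no number is known for it, only that the assay could not place it. Between the two measured compounds there is a single step, an 8.4-fold lower number from compound 2 to compound 3 (0.93 log units; beyond the scatter), which concerns a methyl on an amide-type nitrogen and a different core from that of compound 1.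

The unmeasured compound 4, `CN(C(=O)CNC(=O)CN1CCN(c2ccccc2)CC1)c1ccc(Cl)cc1C(=O)c1ccccc1Cl`, differs from compound 1 in one place: 4-phenylpiperazin-1-yl in place of piperidin-1-yl on a saturated chain carbon bound to a carbonyl carbon. Among the measured compounds shown here, no measured pair shares this change, and the one measured step does not bear on it, since it concerns another position and another core. What is known of compound 1 is only its limit, so the expectation for compound 4 rests on that alone. Compound 4 is expected to remain close to where compound 1 sits, the estimated step being a number no higher from compound 1 to compound 4 (the limit leaves the size open), with a real chance that this assay again reports only a limit. Compound 4 is estimated at 100 mg/kg, within a range of 30 mg/kg to 300 mg/kg.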

Compound 4, dose for half-maximal effect: > 100 mg/kg
Compound 4: no number, only a limit; the forecaster's own chance of this, stated with the estimate: 65%; the middle value sits exactly at the limit.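

In this assay no step can be read from compound 1 to compound 4, because both compounds stand at the same limit and neither has a number: the limit of > 100 mg/kg in this assay, at which 2 of the 4 values shown sit. The compounds shown leave open whether 4-phenylpiperazin-1-yl in place of piperidin-1-yl on a saturated chain carbon bound to a carbonyl carbon changes the dose needed at all.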